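The source may hold more compounds than are shown below. What is called first, only, known or untested is meant among the compounds shown, and "the series" means these compounds.

Working notes on the series in a functional assay on HEK293 cells for antagonist activity at Voltage-dependent L-type calcium channel subunit alpha-1C (Oryctolagus cuniculus), read by FLIPR; a lower number here means a stronger inhibitor, a higher number a weaker inhibitor. Of the compounds shown here, three carry a number so far. Compound 1 `CCOC(=O)C1=C(C)NC(COC(C)=O)=C(C(=O)OCC)C1c1cccc([N+](=O)[O-])c1` gives 10 nM in this assay. Compound 2 `C=CCOC(=O)C1=C(C)NC(C)=C(C(=O)OC)C1c1ccccc1[N+](=O)[O-]` gives 8 nM. Compound 3 `C=CCOC(=O)C1=C(C)NC(C)=C(C(=O)OC)C1c1cccc([N+](=O)[O-])c1` gives 15 nM. Compound 3 holds the highest of the three numbers, but its separation from compound 1 and from compound 2 is within the scatter, so no order among the three can be read. For the measured compounds named here, the one single-point step in the set, a 1.9-fold higher number from compound 2 to compound 3 (0.27 log units; within the scatter), is itself within the scatter; the change there is 3-nitrophenyl in place of 2-nitrophenyl on a saturated ring carbon. Compound 1 and compound 3 differ in more than one place, and their two values lie close together.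

The next compound, compound 4 `COC(=O)C1=C(C)NC(C)=C(C(=O)OCCc2ccc(Cl)cc2)C1c1cccc([N+](=O)[O-])c1`, differs from compound 3 at one ester: 4-chlorobenzyl in place of vinyl on a saturated chain carbon bound to an oxygen next to a carbonyl group. Going by the values given here, no measured step in this set touches an ester, so the change has no precedent here; the only known step, a 1.9-fold higher number from compound 2 to compound 3 (0.27 log units; within the scatter), sits on a different part of the shared core. The expectation is therefore anchored on compound 3 with a wide range. For compound 4 the estimated value in this assay is 12 nM, between 3 nM and 50 nM. The implied step a 1.3-fold lower number from compound 3 to compound 4 (0.10 log units; within the scatter) is expected to stay within the scatter.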

Compound 4, half-maximal inhibitory concentration: 8 nM
The estimate for compound 4 lay 1.5-fold (0.18 log units) above the measured number; measured number inside the range.
By their numbers in this assay, from the lowest: compounds 2, 4, 1 and 3 (each within the scatter of the next).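

In this assay, for the compounds shown here, the exchange of allyloxy for 2-(4-chlorophenyl)ethoxy gives a 1.9-fold lower number from compound 3 to compound 4 (0.27 log units; within the scatter), the first reading at this position, on a saturated chain carbon bound to an oxygen next to a carbonyl group. The entering 4-chlorobenzyl has 8 heavy atoms and one six-membered aromatic ring, against 2 heavy atoms and no ring for the leaving vinyl, yet the step stays within the scatter, so this one pair shows that the position can carry the larger group with no readable loss or gain in this assay. No supporting measurement offers an account of this result.

The compounds shown leave open whether the chlorine contributes anything, since an unsubstituted 2-phenylethyl ester is not among them, and whether a group of a different kind here, such as a terminal amine, a carboxylic acid or a longer chain, would stay within the scatter of compound 3 as well. Going by these compounds, it also remains open whether the same exchange reads the same way with the 2-nitrophenyl of compound 2 in place of the 3-nitrophenyl, because the ester step is known only on the 3-nitrophenyl background.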